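The source may hold more compounds than are shown below. What is called first, only, known or untested is meant among the compounds shown, and "the series" means these compounds.

Compound 1, `O=C(Nc1ccc(Oc2ccnc3[nH]ccc23)c(F)c1)c1nn(-c2ccccc2)ccc1=O`: 56800 nM in a functional assay on A549 cells (Homo sapiens) for cytotoxicity, read by MTT assay, with a stated time of 72 h; a lower number here means a stronger inhibitor, a higher number a weaker inhibitor. Compound 2, `O=C(Nc1ccc(Oc2ccnc3[nH]ccc23)c(F)c1)c1nn(-c2ccc(Br)cc2F)ccc1=O`: 55700 nM in this assay.

Compound 2 has the lowest of the two numbers, with compound 1 nearest; the step of a 1.0-fold lower number from compound 1 to compound 2 (0.01 log units; within the scatter) is within the scatter. Compound 3, `O=C(Nc1ccc(Oc2ccnc3[nH]ccc23)c(F)c1)c1nn(-c2ccc(Cl)c(F)c2)ccc1=O`, carries 4-chloro-3-fluorophenyl in place of 4-bromo-2-fluorophenyl on an aromatic nitrogen. For the measured compounds named here, the one step measured at this position, from compound 1 to compound 2, changed almost nothing, so a change among halogenated phenyl groups here is expected to leave the number where it stands, with no step beyond the scatter: a 1.0-fold lower number from compound 2 to compound 3 (0.01 log units; within the scatter). Compound 3 is therefore estimated at 55000 nM, between 25000 nM and 120000 nM.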

Compound 3, half-maximal inhibitory concentration: 10300 nM
For compound 3 the middle estimate is 5.3-fold (0.73 log units) above the measured one; the measured number lies below the stated range.
By their numbers in this assay, from the lowest: compound 3; then compounds 2 and 1 (each within the scatter of the next).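

This position is not indifferent after all: exchanging one halogenated phenyl for another in this assay gives a real change (a 5.4-fold lower number from compound 2 to compound 3 (0.73 log units; beyond the scatter)), and the 4-chloro-3-fluorophenyl group also stands apart from plain phenyl (a 5.5-fold lower number from compound 1 to compound 3 (0.74 log units; beyond the scatter)). The flat first step therefore did not hold for every halogen pattern on this ring. No measured evidence is available to explain the change.

Halogen identity and placement differ together here, so their contributions cannot be separated. Going by these compounds, how an amine or a carboxylic acid on this phenyl would behave also remains open.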